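The compounds below may be only part of what the source reports. "The series", "measured", "known", "first", "only" and "open" are said of these compounds alone.

Compound 1 `COc1cccc(/C=C/C(=O)N2Cc3ccccc3[C@@H](OCc3ccccc3)[C@@H]2CO)c1OC`: 39800 nM
Compound 2 `COc1cc(/C=C/C(=O)N2Cc3ccccc3[C@@H](OCc3ccccc3)[C@@H]2CO)ccc1O`: 63000 nM

In a functional assay on A549 cells (Homo sapiens) for antiproliferative activity, read by MTT assay, with a stated time of 48 h (a lower number here means a stronger inhibitor, a higher number a weaker inhibitor), compound 2 gives 63000 nM, level with compound 1 within the scatter. Compound 3 `O=C(/C=C/c1ccc([N+](=O)[O-])cc1)N1Cc2ccccc2[C@@H](OCc2ccccc2)[C@@H]1CO` differs from compound 2 in one place: 4-nitrophenyl in place of 4-hydroxy-3-methoxyphenyl on a double-bonded chain carbon bound to a double-bonded chain carbon. Among the measured compounds shown here, the one measured step that bears on this, a 1.6-fold higher number from compound 1 to compound 2 (0.20 log units; within the scatter), also exchanges one substituted phenyl for another at this place and stays within the scatter. For the measured compounds named here, no measured compound carries 4-nitrophenyl, so the evidence is thin. No step beyond the scatter is expected in this assay, and no direction can be favoured. The estimate for compound 3 is 50000 nM, with an expected range from 18000 nM to 130000 nM. That estimate means an expected 1.3-fold lower number from compound 2 to compound 3 (0.10 log units; within the scatter).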

Compound 3, half-maximal inhibitory concentration: 5620 nM
Compound 3: the middle estimate sits 8.9-fold (0.95 log units) above what was measured; the measured number lies below the stated range.
By their numbers in this assay, from the lowest: compound 3; then compounds 1 and 2 (each within the scatter of the next).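

In this assay the steps of an 11-fold lower number from compound 2 to compound 3 (1.05 log units; beyond the scatter) and a 7.1-fold lower number from compound 1 to compound 3 (0.85 log units; beyond the scatter) show that the group on this double-bonded chain carbon can move the number beyond the scatter, with 4-nitrophenyl giving the lower number both times. The earlier exchange between the two oxygen-bearing phenyl groups had shown no such movement. Nothing given here accounts for the drop. Going by these compounds, it remains open how a 4-aminophenyl or a 4-cyanophenyl would compare at this place, and whether an unsubstituted phenyl would stand nearer compound 3 or compound 2.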